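Carboxy group lost at the benzylic amine

The source may report more compounds than this note shows. Statements on the series, on what has been measured and on what is new or still open speak of the compounds shown alone.

Measured in a functional assay on B16-F10 cells (Mus musculus) for antiproliferative activity, read by CCK-8 assay, with a stated time of 48 h (on this read-out lower numbers stand for stronger inhibition and higher numbers for weaker inhibition), all three values being limits of the assay:
- Compound 1 `COc1ccc(/C=C\c2cc(OC)c(OC)c(OC)c2)cc1OCc1ccc(CNC(C)(C)C(=O)O)cc1` gives > 10000 nM as a limit
- Compound 2 `COc1ccc(/C=C\c2cc(OC)c(OC)c(OC)c2)cc1OCc1ccc(CN2C[C@H](O)C[C@@H]2C(=O)O)cc1` gives > 10000 nM as a limit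
- Compound 3 `COc1ccc(/C=C\c2cc(OC)c(OC)c(OC)c2)cc1OCc1ccc(CN2CC(C(=O)O)C2)cc1` gives > 10000 nM as a limit

Compound 3 has no number, only a limit, and it shares the limit of > 10000 nM in this assay, at which 3 of the 3 values shown sit, with the other two compounds.

Compound 4 `COc1ccc(/C=C\c2cc(OC)c(OC)c(OC)c2)cc1OCc1ccc(CN2CC[C@@H](O)C2)cc1` carries 3-hydroxypyrrolidin-1-yl in place of 3-carboxyazetidin-1-yl on a saturated chain carbon bound to an aromatic carbon. The nearest measured steps are a step that the two limits leave unreadable from compound 2 to compound 3 and a step that the two limits leave unreadable from compound 1 to compound 3, so neither offers a size to carry over. Compound 2 holds a hydroxy group alongside its carboxy group and gives only the limit > 10000 nM as well.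

The one contrast available rests on the limit of > 10000 nM in this assay, at which 3 of the 3 values shown sit: every measured compound carries a carboxy group, and compound 4 has none. On that thin basis, the expectation in this assay is a move toward stronger inhibition, with no measured size behind it. The estimated change is an at least 5.0-fold lower number from compound 3 to compound 4 (0.69 log units; beyond the scatter), and a result at the limit would not be surprising. For compound 4 the estimated value is 2000 nM (expected range 100 nM to 10000 nM).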

Compound 4, half-maximal inhibitory concentration: > 10000 nM
Compound 4 was reported as a limit (the forecaster's own chance of this, stated with the estimate: 35%); middle value at least 5.0-fold (0.69 log units) away from the limit.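

In this assay compound 4 gives > 10000 nM, which is a limit of the assay. No new step can be read from this result: the steps linking compound 4 to compound 1, compound 2 and compound 3 cannot be sized. The compounds shown leave open whether any group on the saturated chain carbon bound to an aromatic carbon gives a measurable value, with all of them resting on one limit: the limit of > 10000 nM in this assay, at which 4 of the 4 values shown sit.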